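The compounds below may be only part of what the source reports. "The series", "measured", "known", "first", "only" and "open" are said of these compounds alone.

Measured in an in vivo ADME assay on the whole organism for pharmacokinetics, with Rattus norvegicus as the target, at a dose of 10 mg/kg by the oral route; a higher number here means more compound in the circulation at the dose given, a lower number less compound in the circulation:
- compound 1 (`CCc1cc(CS(=O)(=O)N2CCN(c3cnn(-c4cccc(Cl)c4)c(=O)c3OCC3(C)CC3)CC2)ccc1N`): 4020 nM
- compound 2 (`CC1(COc2c(N3CCN(S(=O)(=O)Cc4ccc(N)nc4)CC3)cnn(-c3cccc(Cl)c3)c2=O)CC1`): 1830 nM

Of these two, compound 2 has the lower number, and compound 1 sits above it by a margin beyond the scatter. The next compound, compound 3 (`CC1(COc2c(N3CCN(S(=O)(=O)Cc4cccnc4N)CC3)cnn(-c3cccc(Cl)c3)c2=O)CC1`), carries 2-aminopyridin-3-yl in place of 6-aminopyridin-3-yl on a saturated chain carbon bound to a sulfonyl sulfur. The rest of compound 2 stays the same.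

For the measured compounds named here, only one measured step bears on this change. It sits at the same place and is modest: a 2.2-fold lower number from compound 1 to compound 2 (0.34 log units; beyond the scatter) in this assay. That step replaced 4-amino-3-ethylphenyl, whereas here one aminopyridinyl group gives way to another with the same atoms. Going by the values given here, no measured compound carries 2-aminopyridin-3-yl, so the data offer no firm direction. A change beyond the usual scatter is therefore not expected, and the estimated step is small (a 1.1-fold lower number from compound 2 to compound 3 (0.06 log units; within the scatter)). Compound 3 is estimated at 1600 nM, with an expected range from 600 nM to 4000 nM.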

Compound 3, maximal plasma concentration: 3120 nM
Compound 3: the middle estimate sits 2.0-fold (0.29 log units) below what was measured; the measured number falls inside the stated range.
By their numbers in this assay, from the lowest: compounds 2, 3 and 1 (each within the scatter of the next, the first and the last beyond it).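

Swapping 6-aminopyridin-3-yl for 2-aminopyridin-3-yl, two groups with the same atoms joined differently, gives a 1.7-fold higher number from compound 2 to compound 3 (0.23 log units; within the scatter) in this assay and so shows that this rearrangement, on a saturated chain carbon bound to a sulfonyl sulfur, does not clearly alter the result. Replacing 4-amino-3-ethylphenyl with 2-aminopyridin-3-yl gives a 1.3-fold lower number from compound 1 to compound 3 (0.11 log units; within the scatter) and so, unlike the step to compound 2, does not separate the two compounds by more than the scatter; an aminopyridinyl group here therefore need not bring a clear difference from compound 1. Nothing measured here explains these numbers.

On these data alone, all three compounds carry an amino group on the ring at this place, so it remains open how plain pyridin-3-yl, with no amino group, would read in this assay. As far as these compounds go, it is also open how much the ethyl group matters alone, since compound 1 differs from the other two in more than that group, and 4-aminophenyl would separate the ethyl group from the change of ring atoms.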